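A few compounds are considered here, and "the series" means these few. Any claim that something is new, unique, unknown or untested is made for them only; others in the source may bear on it.

Compound 1, `CCOC(=O)C1=C(C)N/C(=N\C#N)NC1c1ccccc1`, gives 25% in an assay on HEK293 cells for displacement of a labelled ligand from adenosine receptor A2b (Homo sapiens), with a stated time of 30 min, tested at 1 uM; on this read-out higher numbers stand for more inhibition at the one concentration tested (going by the name of the read-out) and lower numbers for less inhibition. Compound 3, `CC1=C(C(=O)OC(C)C)C(c2ccccc2)NC(=O)N1`, gives 2% in this assay, and compound 2, `CC1=C(C(=O)OC(C)C)C(C2CCCC2)NC(=O)N1`, gives 3%. The change from compound 3 to compound 2 is cyclopentyl in place of phenyl on a saturated ring carbon, and it made a number 1 percentage points higher from compound 3 to compound 2 (within the scatter). Compound 4, `CCOC(=O)C1=C(C)N/C(=N\C#N)NC1C1CCCC1`, is the not yet measured partner of compound 1, and the change is cyclopentyl in place of phenyl on a saturated ring carbon. This is the same kind of change as that from compound 3 to compound 2, though the ring atom beside the place bears an ethoxycarbonyl group in compound 1 and an isopropoxycarbonyl group in compound 3; the difference between the two cores is otherwise not broken down here. Because a number 1 percentage points higher from compound 3 to compound 2 (within the scatter) stayed within the scatter, the step from compound 1 to compound 4 is expected to be small, around a number 2 percentage points lower from compound 1 to compound 4 (within the scatter). Compound 4 is therefore estimated at 23%, likely between 6% and 40%.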

Compound 4, a percentage reported as inhibition, at one concentration (the size of the read-out at that concentration, not a potency): 19%
Estimate against measurement, compound 4: 4 percentage points above, within the range that was stated.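

With this assay as the read-out, the new step for cyclopentyl in place of phenyl on a saturated ring carbon is a number 6 percentage points lower from compound 1 to compound 4 (within the scatter). Set beside the earlier step, the change carries over from one core to the other as far as this read-out can tell: the same change on two cores in this assay, a number 1 percentage points higher (within the scatter) from compound 3 to compound 2 and a number 6 percentage points lower (within the scatter) from compound 1 to compound 4, 7 percentage points apart, within the scatter of two such steps. This does not show that the change is without effect on every core: only two cores are shown, and each number comes from one concentration, which gives no potency.

The compounds shown leave open what an amine or a carboxylic acid would do on that saturated ring carbon. They also leave open how the two cores compare when they differ in only one place.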